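Cytotoxicity notes on three measured analogues and one pending

A few compounds are considered here, and "the series" means these few. Any claim that something is new, unique, unknown or untested is made for them only; others in the source may bear on it.

Compound 1 `Cc1cc(C)cc(C(=O)c2c(OCC(=O)Nc3ccc(S(N)(=O)=O)cc3C)ccc3ccccc23)c1` gives 39100 nM in an ADME assay on C8166 cells (Homo sapiens) for cytotoxicity, read by colorimetric assay and MTT assay; on this read-out higher numbers stand for lower toxicity in this test and lower numbers for higher toxicity in this test. Compound 2 `Cc1ccc(C(=O)c2c(OCC(=O)Nc3ccc(S(N)(=O)=O)cc3C)ccc3ccccc23)c(C)c1` carries 2,4-dimethylphenyl in place of 3,5-dimethylphenyl on a carbonyl carbon and gives 25500 nM in this assay; the step of a 1.5-fold lower number from compound 1 to compound 2 (0.19 log units; within the scatter). Compound 3 `Cc1cc(C)cc(C(=O)c2c(OCC(=O)Nc3ccc(S(N)(=O)=O)cc3C)ccc3cc(Br)ccc23)c1` gives 24500 nM in this assay; the step of a 1.6-fold lower number from compound 1 to compound 3 (0.20 log units; within the scatter). All three numbers sit close together.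

Compound 4 `Cc1ccc(C(=O)c2c(OCC(=O)Nc3ccc(S(N)(=O)=O)cc3C)ccc3cc(Br)ccc23)c(C)c1` is not yet measured. It carries 2,4-dimethylphenyl in place of 3,5-dimethylphenyl on a carbonyl carbon, the same change already made from compound 1 to compound 2, since the place is described in the same words in both cases. The core of compound 3 differs from that of compound 1 by bromo in place of hydrogen on an aromatic carbon.

For compound 4 in this assay the expected step is a 1.4-fold lower number from compound 3 to compound 4 (0.13 log units; within the scatter), because the measured 1.5-fold lower number from compound 1 to compound 2 (0.19 log units; within the scatter) stayed within the scatter and nothing here suggests a different size. Compound 4 is therefore estimated at 18000 nM, between 9000 nM and 36000 nM.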

Compound 4, half-maximal cytotoxic concentration: 61400 nM
Estimate against measurement, compound 4: 3.4-fold (0.53 log units) below; measured number above the stated range.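

In this assay, 2,4-dimethylphenyl in place of 3,5-dimethylphenyl on the core carrying bromo gives a 2.5-fold higher number from compound 3 to compound 4 (0.40 log units; beyond the scatter), and bromo in place of hydrogen on the core carrying 2,4-dimethylphenyl gives a 2.4-fold higher number from compound 2 to compound 4 (0.38 log units; beyond the scatter). The dimethylphenyl change does not carry from one core to the other at a fixed size: the same change on two cores in this assay, a 1.5-fold lower number (0.19 log units; within the scatter) from compound 1 to compound 2 and a 2.5-fold higher number (0.40 log units; beyond the scatter) from compound 3 to compound 4, 3.8-fold (0.58 log units) apart, beyond the scatter of two such steps. The bromo change behaves the same way, which shows that the two changes do not simply add in these four compounds, but does not show why or how far this extends: the same change on two cores in this assay, a 1.6-fold lower number (0.20 log units; within the scatter) from compound 1 to compound 3 and a 2.4-fold higher number (0.38 log units; beyond the scatter) from compound 2 to compound 4, 3.8-fold (0.58 log units) apart, beyond the scatter of two such steps.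

From the compounds shown here alone, whether chloro or methoxy in place of bromo would repeat this result remains open. So does whether an unsubstituted phenyl on the carbonyl carbon would follow either dimethylphenyl group.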